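Removing methylsulfanyl from compound 2

The source may hold more compounds than are shown below. What is called first, only, known or untested is meant among the compounds shown, and "the series" means these compounds.

Compound 1 `CSc1nc2n(n1)C(c1ccc(O)cc1O)C([N+](=O)[O-])=NN2` gives 201000 nM
Compound 2 `CSc1nc2n(n1)C(c1c(O)cc(O)cc1O)C([N+](=O)[O-])=NN2` gives 877000 nM
Compound 3 `O=[N+]([O-])C1=NNc2ncnn2C1c1c(O)cc(O)cc1O` awaits measurement

Within the data shown here, in an ADME assay on MDCK cells (Canis lupus familiaris) for cytotoxicity (a higher number here means that more compound is tolerated, a lower number that less compound is tolerated), compound 2 stands highest of the two measured compounds, and the one measured step is a 4.4-fold higher number from compound 1 to compound 2 (0.64 log units; beyond the scatter). Compound 3 differs from compound 2 by hydrogen in place of methylsulfanyl on an aromatic carbon. Among the measured compounds shown here, the measured step was a different change, hydroxy in place of hydrogen on an aromatic carbon, and no measured step removes methylsulfanyl. It gives no firm guide in size or direction, so no step beyond the scatter is expected, and the estimated step is a 1.5-fold lower number from compound 2 to compound 3 (0.16 log units; within the scatter). The estimate for compound 3 is 600000 nM, within an expected range from 200000 nM to 1500000 nM.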

Compound 3, half-maximal cytotoxic concentration: 119000 nM
Estimate against measurement, compound 3: 5.0-fold (0.70 log units) above; measured number outside the range, below it.
By their numbers in this assay, from the lowest: compounds 3 and 1 (each within the scatter of the next); then compound 2.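

In this assay, the position carrying methylsulfanyl turns out to matter: hydrogen in its place gives a 7.4-fold lower number from compound 2 to compound 3 (0.87 log units; beyond the scatter) and so less compound is tolerated. Among these compounds, the earlier step showed only a change of hydroxy on an aromatic carbon elsewhere, so this is the first sign that this substituent also moves the number. Nothing measured here explains the loss.

On these data alone, whether an amine or a longer chain such as ethylsulfanyl at this position would keep the higher number remains open. So does whether the same step would hold with the hydroxy arrangement of compound 1.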